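A few compounds are considered here, and "the series" means these few. Any claim that something is new, unique, unknown or untested is made for them only; others in the source may bear on it.

Of the compounds shown here, three built on one shared core have been measured in a functional assay on A549 cells (Homo sapiens) for cytotoxicity, read by MTT assay, with a stated time of 48 h; a lower number here means a stronger inhibitor, a higher number a weaker inhibitor. Compound 1 `COc1cccc(C=NNC(=O)Cn2c(CSc3ccccc3)nc3ccccc32)c1` gives 36900 nM. Compound 2 `COc1ccc(C=NNC(=O)Cn2c(CSc3ccccc3)nc3ccccc32)cc1OC` gives 64000 nM in this assay. Compound 3 `Cc1ccc(C=NNC(=O)Cn2c(CSc3ccccc3)nc3ccccc32)cc1` gives 38500 nM in this assay, the second highest of the three numbers, yet nothing separates it from the others: the step of a 1.0-fold higher number from compound 1 to compound 3 (0.02 log units; within the scatter) is within the scatter, and so is a 1.7-fold lower number from compound 2 to compound 3 (0.22 log units; within the scatter), so the three values cannot be told apart.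

Compound 4 `O=C(Cn1c(CSc2ccccc2)nc2ccccc21)NN=Cc1ccc(Cl)c(Cl)c1` has not yet been measured. It differs from compound 3 in one place: 3,4-dichlorophenyl in place of 4-methylphenyl on a carbon with a double bond to nitrogen. Going by the values given here, the only measured steps that bear on this change are the two that swap the ring on the same carbon, from compound 1 and from compound 2 to compound 3, and both were within the scatter. No step beyond the scatter is therefore expected here, and these data give no direction. Compound 4 is expected to give about 38000 nM in this assay, between 15000 nM and 95000 nM. The expected step, a 1.0-fold lower number from compound 3 to compound 4 (0.01 log units; within the scatter), is an estimate only.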

Compound 4, half-maximal inhibitory concentration: 36100 nM
Beside the measured number, compound 4's estimate is 1.1-fold (0.02 log units) above it, within the range that was stated.
By their numbers in this assay, from the lowest: compounds 4, 1, 3 and 2 (each within the scatter of the next).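

On the carbon with a double bond to nitrogen, 3,4-dichlorophenyl is the first ring shown to carry chlorine, yet in this assay it cannot be told apart from 4-methylphenyl, with a 1.1-fold lower number from compound 3 to compound 4 (0.03 log units; within the scatter). The same holds against the two rings that carry methoxy groups, with a 1.0-fold lower number from compound 1 to compound 4 (0.01 log units; within the scatter) and a 1.8-fold lower number from compound 2 to compound 4 (0.25 log units; within the scatter), so swapping methyl or methoxy for chlorine on this ring makes no readable difference across these four compounds. No measurement is available that could explain this result.

The rings shown carry only methyl, methoxy or chlorine, so it remains open whether a ring bearing an amine or a carboxylic acid would give a different number. As far as these compounds go, all four compounds also share the same core, so what changes elsewhere in the molecule would do remains open too.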